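One halogen change, two related cores, one expectation

This account rests on a few compounds, and the source may have more. Where it says the series, first, only, none or still open, it means among the compounds named here.

Compound 1 `O=C(CCCCCCN1C(=O)/C(=N\O)c2cc(F)ccc21)NO` and compound 2 `O=C(CCCCCCN1C(=O)/C(=N\O)c2cc(Cl)ccc21)NO` share a core and differ at a single point: chloro in place of fluoro on an aromatic carbon. In a functional assay on MCF7 cells (Homo sapiens) for antiproliferative activity, read by sulforhodamine B assay, with a stated time of 48 h (a lower number here means a stronger inhibitor, a higher number a weaker inhibitor), compound 1 gives 1550 nM, and in this assay compound 2 gives 680 nM. This produced a 2.3-fold lower number from compound 1 to compound 2 (0.36 log units; beyond the scatter). Compound 3 `CO/N=C1/C(=O)N(CCCCCCC(=O)NO)c2ccc(F)cc21` rests on a different core; how the cores of compound 1 and compound 3 differ is not broken down here. In this assay compound 3 gives 2420 nM, a number that lies within the usual scatter of compound 1 and is higher than that of compound 2. Compound 4 `CO/N=C1/C(=O)N(CCCCCCC(=O)NO)c2ccc(Cl)cc21` has not yet been measured in this assay. It differs from compound 3 by the same change seen before: chloro in place of fluoro on an aromatic carbon. Going by the values given here, with only one measured example of this change, that example is the whole basis for what follows. Because the earlier pair gave a 2.3-fold lower number from compound 1 to compound 2 (0.36 log units; beyond the scatter), a step of about the same size is expected for compound 4, namely a 2.2-fold lower number from compound 3 to compound 4 (0.34 log units; beyond the scatter). The estimate for compound 4 in this assay is 1100 nM, expected to fall between 500 nM and 2400 nM.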

Compound 4, half-maximal inhibitory concentration: 1560 nM
Compound 4: middle estimate off by 1.4-fold (0.15 log units), on the low side; measured number inside the range.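

In this assay, chloro in place of fluoro on the second core gave a 1.6-fold lower number from compound 3 to compound 4 (0.19 log units; within the scatter), so this step alone does not establish a real difference between the two compounds. Set beside the step on the first core, it agrees as closely as measurements of this kind can show: the same change on two cores in this assay, a 2.3-fold lower number (0.36 log units; beyond the scatter) from compound 1 to compound 2 and a 1.6-fold lower number (0.19 log units; within the scatter) from compound 3 to compound 4, 1.5-fold (0.17 log units) apart, within the scatter of two such steps. The size of the step seen on the first core therefore fits the second core as well, but two pairs are a small base, and they show neither why the two halogens differ nor that the step would hold on any further core.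

The compounds shown leave open how a bromo or a methyl group at this same place on the aromatic ring would compare with fluoro and chloro. They also leave open whether the step would stay the same with a longer chain carrying the hydroxamic acid.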